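This account rests on a few compounds, and the source may have more. Where it says the series, first, only, none or still open, it means among the compounds named here.

Measured compounds:
Compound 1 `COc1ccc(/C=C/C(=O)c2cc3ccc(OCc4cccc(OC)c4)cc3oc2=O)cc1` reaches only a limit in a functional assay on K562 cells (Homo sapiens) for cytotoxicity, read by MTT assay, with a stated time of 72 h (on this read-out higher numbers stand for weaker inhibition and lower numbers for stronger inhibition), namely > 100000 nM.
Compound 2 `COc1cccc(/C=C/C(=O)c2cc3cc(OCc4ccccc4)ccc3oc2=O)c1OC` gives 48900 nM in this assay.
Compound 3 `COc1cc(/C=C/C(=O)c2cc3cc(OCc4ccccc4)ccc3oc2=O)cc(OC)c1OC` gives 66400 nM in this assay.

Compound 1 therefore stands at the limit of this assay, with no number of its own (the limit of > 100000 nM in this assay, at which 1 of the 3 values shown sits). The unmeasured compound 4 `COc1cccc(COc2ccc3cc(C(=O)/C=C/c4cccc(OC)c4OC)c(=O)oc3c2)c1` differs from compound 1 in one place: 2,3-dimethoxyphenyl in place of 4-methoxyphenyl on a double-bonded chain carbon bound to a double-bonded chain carbon. Among the compounds with values here, no step between measured compounds is available, so the size of this change cannot be read from the data; since compound 1 sits at a limit, any step in this assay can only be none beyond the scatter or a move toward stronger inhibition. Compound 4 is expected at 70000 nM, between 30000 nM and 100000 nM, because compound 2, which also carries a 2,3-dimethoxyphenyl, gives 48900 nM. The estimated step is an at least 1.4-fold lower number from compound 1 to compound 4 (0.15 log units; that floor lies within the scatter).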

Compound 4, half-maximal inhibitory concentration: 45500 nM
Estimate against measurement, compound 4: 1.5-fold (0.19 log units) above; the range from low to high includes it.
By their numbers in this assay, from the lowest: compounds 4, 2 and 3 (each within the scatter of the next). At a limit, above all of these: compound 1.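

With an at least 2.1-fold lower number from compound 1 to compound 4 (0.34 log units; beyond the scatter) as the first step that can be read here, 2,3-dimethoxyphenyl in place of 4-methoxyphenyl on a double-bonded chain carbon bound to a double-bonded chain carbon is shown to lower the number in this assay beyond the scatter. This step is only a floor, since compound 1 has a limit and no number of its own: the limit of > 100000 nM in this assay, at which 1 of the 4 values shown sits.

Going by these compounds, the full size of the step therefore stays open. Also open, on these data alone, is how an amine or a carboxylic acid on this phenyl ring would read out.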